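A few compounds are considered here, and "the series" means these few. Any claim that something is new, unique, unknown or untested is made for them only; others in the source may bear on it.

Compound 1 `CC(C)=CCCC1=CC[C@H](C(=O)NCCC(=O)O)[C@@H](c2ccccc2)C1`: > 23000 nM
Compound 2 `CC1(C)CCCC2=C1C[C@@H](C(=O)O)[C@H](c1ccccc1)C2`: > 23000 nM

In an assay on isolated protein for inhibition of Apoptosis regulator Bcl-2 (Homo sapiens), read by fluorescence polarization, with stated times of 5 min and 10 min (a lower number here means a stronger inhibitor, a higher number a weaker inhibitor), compound 1 gives > 23000 nM, which is a limit of the assay rather than a number. Compound 2 likewise gives > 23000 nM, again only a limit. Both results sit at the limit of > 23000 nM in this assay, at which 2 of the 2 values shown sit, so compound 1 has no measured position other than that edge. Compound 3 `CC(C)=CCCC1=CC[C@H](C(=O)N(C)O)[C@@H](c2ccccc2)C1` differs from compound 1 in one place: hydroxy(methyl)amino in place of (2-carboxyethyl)amino on a carbonyl carbon. Among the compounds with values here, no step between measured compounds is available to guide a forecast, so no change beyond the usual scatter is expected in this assay. Compound 3 is therefore expected to come out near 30000 nM, somewhere between 8000 nM and 100000 nM, an expected step that the limit leaves unreadable from compound 1 to compound 3.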

Compound 3, inhibition constant: 2100 nM
The estimate for compound 3 lay 14-fold (1.15 log units) above the measured number, outside the stated range (below it).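

In this assay, the group on this carbonyl carbon decides whether the core of compound 1 gives a readable number at all: hydroxy(methyl)amino in place of (2-carboxyethyl)amino gives an at least 10-fold lower number from compound 1 to compound 3 (1.03 log units; beyond the scatter). The true size of this step stays unknown, because compound 1 gives only a limit of the assay: the limit of > 23000 nM in this assay, at which 2 of the 3 values shown sit.

The compounds shown do not separate the part played by the hydroxy from that of the methyl on the nitrogen. As far as these compounds go, what a plain methylamino or a methoxy(methyl)amino group would give on this carbonyl carbon also remains open.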